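Chain length at the ring nitrogen: from hexyl to octyl

The source may hold more compounds than are shown below. What is called first, only, known or untested is meant among the compounds shown, and "the series" means these compounds.

The measured compounds and their values in an assay on microsomes from intestine for inhibition of acyl-CoA:cholesterol acyltransferase (Oryctolagus cuniculus); a higher number here means a weaker inhibitor, a lower number a stronger inhibitor:
Compound 1, `CC(C)c1cccc(C(C)C)c1NC(=O)NC1=NN(Cc2ccccc2)NN1`, gives 370 nM.
Compound 2, `CCCCN1NN=C(NC(=O)Nc2c(C(C)C)cccc2C(C)C)N1`, gives 92 nM.
Compound 3, `CCCCCCN1NN=C(NC(=O)Nc2c(C(C)C)cccc2C(C)C)N1`, gives 73 nM.

Compound 3 has the lowest number of the three. Its nearest neighbour is compound 2: the step of a 1.3-fold lower number from compound 2 to compound 3 (0.10 log units; within the scatter) lies within the scatter, so the two cannot be ordered on these data. Compound 1 stands furthest away: compound 1 gives 370 nM, whereas compound 3 gives 73 nM, and this gap is beyond the scatter.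

The next compound, compound 4, `CCCCCCCCN1NN=C(NC(=O)Nc2c(C(C)C)cccc2C(C)C)N1`, differs from compound 3 by ethyl in place of hydrogen on a saturated chain carbon, six bonds along the chain from an amine nitrogen in a ring. Among the compounds with values here, only one measured step bears on this change, the extension from compound 2 to compound 3, which lengthened the same chain by the same two carbons and gave a change within the scatter. Nothing in the series suggests that a further extension of the same kind should behave differently, so the step from compound 3 to compound 4 is expected to be small, a 1.2-fold lower number from compound 3 to compound 4 (0.09 log units; within the scatter), with the direction uncertain. Compound 4 is therefore estimated at 60 nM in this assay, within a range from 25 nM to 150 nM.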

Compound 4, half-maximal inhibitory concentration: 59 nM
For compound 4 the middle estimate is 1.0-fold (0.01 log units) above the measured one; the measured number falls inside the stated range.
By their numbers in this assay, from the lowest: compounds 4, 3 and 2 (each within the scatter of the next); then compound 1.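

The octyl compound extends what was a single step into a run of three chain lengths in this assay: adding ethyl six bonds along the chain from the ring amine nitrogen gives the step (a 1.2-fold lower number from compound 3 to compound 4 (0.09 log units; within the scatter)), and this is again within the scatter. The new information lies in the longer comparison, since the full change, butyl in place of hydrogen four bonds along the chain, gives the step (a 1.6-fold lower number from compound 2 to compound 4 (0.19 log units; within the scatter)), so two successive extensions taken together still do not move the value beyond the scatter, and compounds 2, 3 and 4 cannot be ordered on these data. No independent measurement accompanies these values that could account for this insensitivity to chain length.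

The compounds shown leave open whether a longer chain, such as decyl or dodecyl, would remain within the scatter of these three, or whether a shorter one, such as methyl, would do so. They also leave open how a chain carrying a carboxylic acid or an amine would behave at this ring nitrogen.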